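The compounds below may be only part of what the source reports. "The series", "measured", "known", "first", "only" and "open" are said of these compounds alone.

Working notes on the series. Compound 1 `COc1ccc(-n2c(=O)n(Cc3cc4cc(Cl)ccc4n3CCCC#N)c3cnccc32)cc1OC` and compound 2 `N#CCCCn1c(Cn2c(=O)n(-c3ncco3)c3ccncc32)cc2cc(Cl)ccc21` share one core and differ only at an aromatic nitrogen. In an ADME assay on HeLa cells (Homo sapiens) for cytotoxicity, read by ATP content, with a stated time of 3 days (a higher number here means that more compound is tolerated, a lower number that less compound is tolerated), compound 1 gives > 50000 nM, which is a limit of the assay and not a number. In this assay compound 2 likewise gives > 50000 nM, again a limit and not a number. The step from compound 1 to compound 2 is therefore a step that the two limits leave unreadable from compound 1 to compound 2, because of the limit of > 50000 nM in this assay, at which 2 of the 2 values shown sit. Going by the values given here, compound 2 thus stands only at a limit, and the one further value shown for comparison is a limit as well.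

Compound 3 `N#CCCCn1c(Cn2c(=O)n(-c3ccncc3F)c3ccncc32)cc2cc(Cl)ccc21` differs from compound 2 by 3-fluoropyridin-4-yl in place of 1,3-oxazol-2-yl on an aromatic nitrogen. Among the compounds with values here, the only measured step that bears on this position, the exchange at the same ring nitrogen going from compound 1 to compound 2, is unreadable, so it gives no size of step in either direction. Nothing in the two measured compounds points to a half-maximal cytotoxic concentration within the tested range. The step from compound 2 to compound 3 in this assay is expected to be a step that the limit leaves unreadable from compound 2 to compound 3. Compound 3 is accordingly estimated at 60000 nM, within 25000 nM to 150000 nM, most likely reported again as a limit.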

Compound 3, half-maximal cytotoxic concentration: > 50000 nM
Compound 3: a limit, no number (the forecaster's own chance of this, stated with the estimate: 80%); the middle value is on the limit's open side.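

In this assay compound 3 gives > 50000 nM, a limit of the assay and not a number. The steps among compound 1, compound 2 and compound 3 cannot be read, because all three stop at the same point: the limit of > 50000 nM in this assay, at which 3 of the 3 values shown sit. The compounds shown leave open whether the exchanges on the aromatic nitrogen change the half-maximal cytotoxic concentration at all.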